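Toward compound 3: replacing the 4-chlorobutyl group

This account rests on a few compounds, and the source may have more. Where it says the series, first, only, none or still open, it means among the compounds named here.

Measured in a functional assay on KYSE-450 cells (Homo sapiens) for inhibition, read by MTT assay, with a stated time of 48 h; a lower number here means a stronger inhibitor, a higher number a weaker inhibitor:
- compound 1 `CCC/C=C/C(=O)N(Cc1ccc(OC)c(O)c1)c1cc(OC)c(OC)c(OC)c1`: 57 nM
- compound 2 `COc1ccc(CN(C(=O)CCCCCl)c2cc(OC)c(OC)c(OC)c2)cc1O`: 770 nM

Going by the values given here, compound 2 holds the higher of the two numbers, and only one measured step reaches it: a 14-fold higher number from compound 1 to compound 2 (1.13 log units; beyond the scatter), large and beyond the scatter. The next structure is compound 3 `COc1ccc(CN(C(=O)/C=C/CBr)c2cc(OC)c(OC)c(OC)c2)cc1O`, with 3-bromoprop-1-en-1-yl in place of 4-chlorobutyl on a carbonyl carbon. This puts 3-bromoprop-1-en-1-yl in place of 4-chlorobutyl on a carbonyl carbon. The measured step bears on this change. Among the compounds with values here, its other partner, pent-1-en-1-yl, also has a double bond, but no measured compound carries bromine and one step is thin evidence. A move in this assay toward a lower number is therefore expected, though probably smaller than the measured step. The expected step is a 3.9-fold lower number from compound 2 to compound 3 (0.59 log units; beyond the scatter). The estimated value for compound 3 is 200 nM, with an expected range of 45 nM to 900 nM.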

Compound 3, half-maximal inhibitory concentration: 100 nM
Compound 3: middle estimate off by 2.0-fold (0.30 log units), on the high side; the range from low to high includes it.
By their numbers in this assay, from the lowest: compounds 1 and 3 (each within the scatter of the next); then compound 2.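

In this assay, the change on the carbonyl carbon from 4-chlorobutyl to 3-bromoprop-1-en-1-yl gives a clear gain (a 7.7-fold lower number from compound 2 to compound 3 (0.89 log units; beyond the scatter)), so a halogen-bearing chain at this position need not carry the penalty seen with compound 2. Bromo in place of ethyl on a saturated chain carbon bound to a double-bonded chain carbon makes no difference beyond the scatter (a 1.8-fold higher number from compound 1 to compound 3 (0.24 log units; within the scatter)), and among these three compounds, the two with a double bond in this chain stand together, apart from compound 2. No available evidence explains these differences.

The step from compound 2 to compound 3 changes the double bond, the halogen and the chain length together, so the share of each remains unresolved. Open too, going by these compounds, is how this position would respond to a 4-bromobutyl chain, or to an amine or carboxylic acid at the end of the chain.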